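The source may hold more compounds than are shown below. What is called first, only, known or untested is meant among the compounds shown, and "the series" means these compounds.

Series notes. Going by the values given here, compound 1 `COc1ncccc1C(=O)Nc1cnn(Cc2c(C)noc2C)c1` gives 1100 nM in a functional assay on cells for antagonist activity at taste receptor type 2 member 8 (Homo sapiens), read by FLIPR and calcium flux, with a stated time of 100 s (a higher number here means a weaker inhibitor, a lower number a stronger inhibitor), and stands highest of the three numbers measured so far. Compound 2 `Cc1noc(C)c1Cn1cc(NC(=O)c2ccc(O)cc2)cn1` gives 500 nM, and compound 3 `Cc1noc(C)c1Cn1cc(NC(=O)c2ccc3[nH]ccc3c2)cn1` gives 300 nM. Among the compounds with values here, the only single-point step measured, a 2.2-fold lower number from compound 1 to compound 2 (0.34 log units; beyond the scatter), is modest and is also the only step that exchanges the group on the carbonyl carbon. Compound 4 `Cc1noc(C)c1Cn1cc(NC(=O)Nc2ccccc2)cn1` differs from compound 1 in that same region: anilino in place of 2-methoxypyridin-3-yl on a carbonyl carbon. Within the data shown here, no measured pair brings anilino onto the carbonyl carbon, so the expectation rests on compound 2 alone, whose step a 2.2-fold lower number from compound 1 to compound 2 (0.34 log units; beyond the scatter) points to a modest lowering of the number from compound 1 rather than none. Compound 4 is therefore expected to show a 1.8-fold lower number from compound 1 to compound 4 (0.26 log units; within the scatter). The estimate for compound 4 is 600 nM, with a range from 250 nM to 1500 nM.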

Compound 4, half-maximal inhibitory concentration: 2000 nM
Compound 4: the middle estimate sits 3.3-fold (0.52 log units) below what was measured; measured number above the stated range.
By their numbers in this assay, from the lowest: compounds 3 and 2 (each within the scatter of the next); then compounds 1 and 4 (each within the scatter of the next).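

Anilino on the carbonyl carbon does not carry over the lowering seen with 4-hydroxyphenyl: the change gives a 1.8-fold higher number from compound 1 to compound 4 (0.26 log units; within the scatter) and stays level with 2-methoxypyridin-3-yl, whereas a 4.0-fold higher number from compound 2 to compound 4 (0.60 log units; beyond the scatter) and separates it from 4-hydroxyphenyl. A six-membered aromatic ring in this region therefore does not by itself secure the lower number of compound 2. Nothing available explains this difference. Still open, going by these compounds, is whether anilino bearing a hydroxy group, or a saturated amine such as piperidin-1-yl on the carbonyl carbon, would reach the number of compound 2.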